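Fluoro in Place of Methyl on a Dimethylphenyl Ring

A few compounds are considered here, and "the series" means these few. Any claim that something is new, unique, unknown or untested is made for them only; others in the source may bear on it.

In a functional assay on SW-620 cells (Homo sapiens) for cytotoxicity (a higher number here means a weaker inhibitor of growth, a lower number a stronger inhibitor of growth), compound 1 (`COc1ccc(C2=C(c3ccc(SC)cc3)CC3CCCN3C2=O)cc1O`), bearing 3-hydroxy-4-methoxyphenyl, gives 20000 nM and stands highest of the three numbers. Compound 2 (`CSc1ccc(C2=C(c3ccc(F)c(F)c3)C(=O)N3CCCC3C2)cc1`), bearing 3,4-difluorophenyl on the same core, gives 200 nM and stands lowest. Compound 3 (`CSc1ccc(C2=C(c3ccc(C)c(C)c3)C(=O)N3CCCC3C2)cc1`), bearing 3,4-dimethylphenyl, gives 700 nM and so lies in the middle, nearer to compound 2 than to compound 1.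

Compound 4 (`CSc1ccc(C2=C(c3ccc(F)c(C)c3)C(=O)N3CCCC3C2)cc1`) places fluoro in place of methyl on an aromatic carbon of compound 3 (fluoro in place of methyl on an aromatic carbon) and turns 3,4-dimethylphenyl into 4-fluoro-3-methylphenyl. The closest evidence is a 3.5-fold higher number from compound 2 to compound 3 (0.54 log units; beyond the scatter) on going from difluoro to dimethyl. Compound 4 mixes the two groups, with fluoro as in compound 2 and methyl as in compound 3, so part of that modest step is expected back, towards a lower number. The larger steps of a 100-fold lower number from compound 1 to compound 2 (2.00 log units; beyond the scatter) and a 29-fold lower number from compound 1 to compound 3 (1.46 log units; beyond the scatter) both start from a different aryl group and say little about this exchange. The data do not show whether the two groups contribute equally. The expected outcome is a 1.9-fold lower number from compound 3 to compound 4 (0.28 log units; within the scatter) and may not clear the scatter. Compound 4 is estimated at 370 nM with an expected range of 170 nM to 800 nM in this assay.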

Compound 4, concentration for 50% growth inhibition: 600 nM
For compound 4 the middle estimate is 1.6-fold (0.21 log units) below the measured one, within the range that was stated.
By their numbers in this assay, from the lowest: compound 2; then compounds 4 and 3 (each within the scatter of the next); then compound 1.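

At the ring carbon para to a large group and ortho to a methyl group, this assay does not distinguish fluoro from methyl: a 1.2-fold lower number from compound 3 to compound 4 (0.07 log units; within the scatter) leaves the two compounds within the scatter of each other. Compound 4 shares one fluoro with compound 2, yet a 3.0-fold higher number from compound 2 to compound 4 (0.48 log units; beyond the scatter) is close in size to a 3.5-fold higher number from compound 2 to compound 3 (0.54 log units; beyond the scatter), so among these three compounds, the single exchange of fluoro for methyl that moves the number beyond the scatter is the one that turns 3,4-difluorophenyl into 4-fluoro-3-methylphenyl. The 4-fluoro-3-methylphenyl group also stands well clear of the 3-hydroxy-4-methoxyphenyl group, with a 33-fold lower number from compound 1 to compound 4 (1.52 log units; beyond the scatter), but nothing measured here accounts for any of these steps.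

The compounds shown leave open whether 3-fluoro-4-methylphenyl, the arrangement with the two groups exchanged, would stay with compound 2 or with compound 3 and compound 4. They also leave open whether a larger chloro atom, an amine or a longer chain on the same carbon would stay within the scatter of compound 3 or move the number beyond it.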